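The compounds below may be only part of what the source reports. "The series", "measured", "known", "first", "only" and "open" are said of these compounds alone.

Four close relatives share one core, and each carries a substituted phenyl on a carbonyl carbon. Compound 1 `COc1cc(C(=O)c2sc(Nc3ccc(C)cc3)nc2N)cc(OC)c1OC`, compound 2 `COc1ccc(Nc2nc(N)c(C(=O)c3ccccc3OC)s2)cc1` and compound 3 `COc1ccccc1C(=O)c1sc(Nc2ccccc2)nc1N` have been tested in a functional assay on L1210 cells (Mus musculus) for antiproliferative activity, read by cell counting, with a stated time of 2 days; on this read-out lower numbers stand for stronger inhibition and higher numbers for weaker inhibition. In this assay compound 1 gives 31 nM, compound 2 gives 31 nM, and compound 3 gives 1100 nM. Compound 2 therefore sits level with compound 1 at the digits shown; together they hold the lowest of the three numbers, while the only large movement in the set is a 35-fold higher number from compound 2 to compound 3 (1.55 log units; beyond the scatter). Compound 4 `COc1ccc(Nc2nc(N)c(C(=O)c3cccc(OC)c3)s2)cc1` has not yet been measured. The change from compound 2 is 3-methoxyphenyl in place of 2-methoxyphenyl on a carbonyl carbon. Among the measured compounds shown here, no measured step moves a methoxy around the same ring while keeping it; the one step that bears on it only removes the group, and it was large. The methoxy is kept in compound 4, so a loss of that size is not expected, yet some weakening seems more likely than none, and the estimated step is a 4.8-fold higher number from compound 2 to compound 4 (0.68 log units; beyond the scatter). Compound 4 is expected to give about 150 nM, within a range of 25 nM to 1200 nM.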

Compound 4, half-maximal inhibitory concentration: 35 nM
Compound 4: the middle estimate sits 4.3-fold (0.63 log units) above what was measured; the range from low to high includes it.
By their numbers in this assay, from the lowest: compounds 1, 2 and 4 (each within the scatter of the next); then compound 3.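

In this assay, putting 3-methoxyphenyl in place of 2-methoxyphenyl on a carbonyl carbon gives a 1.1-fold higher number from compound 2 to compound 4 (0.05 log units; within the scatter) and so leaves the read-out within the usual scatter. At this place, then, the methoxy can sit at either of these two ring positions with no measurable difference between the two compounds. The large step, a 35-fold higher number from compound 2 to compound 3 (1.55 log units; beyond the scatter), belongs to a different place, since compound 3 keeps its 2-methoxyphenyl and loses the methoxy on the other aromatic ring, so that step says nothing about the ring studied here. Still open is whether this ring needs a methoxy at all, as the compounds shown include no plain phenyl here and no ring carrying ethoxy, hydroxy or an amine such as dimethylamino instead. No measurement shown gives a reason for either step.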